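A 2-nitrophenyl isomer of compound 2

The source may report more compounds than this note shows. Statements on the series, on what has been measured and on what is new or still open speak of the compounds shown alone.

Measured in a functional assay on A549 cells (Homo sapiens) for antiproliferative activity, read by MTT assay, with a stated time of 72 h; on this read-out lower numbers stand for stronger inhibition and higher numbers for weaker inhibition:
Compound 1 `Nc1nc(N)c2cc(CSC(=S)N3CCN(c4ccc(F)cc4F)CC3)ccc2n1`: 5120 nM
Compound 2 `Nc1nc(N)c2cc(CSC(=S)N3CCN(c4ccc([N+](=O)[O-])cc4)CC3)ccc2n1`: 1910 nM

Compound 2 holds the lower of the two numbers. Compound 3 `Nc1nc(N)c2cc(CSC(=S)N3CCN(c4ccccc4[N+](=O)[O-])CC3)ccc2n1` differs from it in one group: 2-nitrophenyl in place of 4-nitrophenyl on an amine nitrogen in a ring. Among the measured compounds shown here, the only measured step, a 2.7-fold lower number from compound 1 to compound 2 (0.43 log units; beyond the scatter), is modest and concerns a different group, so it suggests a size but no direction. A step no larger is expected in this assay, more likely upward, since a low value such as 1910 nM for compound 2 leaves the higher side more open. The estimated step is a 1.6-fold higher number from compound 2 to compound 3 (0.20 log units; within the scatter) here. Compound 3 is estimated at 3000 nM (expected range 1100 nM to 8000 nM).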

Compound 3, half-maximal inhibitory concentration: 4360 nM
The estimate for compound 3 lay 1.5-fold (0.16 log units) below the measured number; low and high end bracket the measured number.
By their numbers in this assay, from the lowest: compound 2; then compounds 3 and 1 (each within the scatter of the next).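

In this assay, 2-nitrophenyl in place of 4-nitrophenyl on the ring amine nitrogen gives a 2.3-fold higher number from compound 2 to compound 3 (0.36 log units; beyond the scatter), so with the same atoms, where the nitro group sits on the phenyl ring matters at this position. Against 2,4-difluorophenyl, 2-nitrophenyl gives a 1.2-fold lower number from compound 1 to compound 3 (0.07 log units; within the scatter), so the advantage seen with 4-nitrophenyl does not extend to its isomer. Nothing available explains this difference. Open, as far as these compounds go, is whether the effect belongs to the nitro group itself, or whether a 4-aminophenyl or 4-methoxyphenyl group on the same nitrogen would give a similar number.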